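Methoxy on the lactone ring carbon: compound 4

A few compounds are considered here, and "the series" means these few. Any claim that something is new, unique, unknown or untested is made for them only; others in the source may bear on it.

Inhibition in this series was measured in a functional assay on RAW264.7 cells (Mus musculus) for inhibition, with a stated time of 24 h; a higher number here means a weaker inhibitor, a lower number a stronger inhibitor.
compound 1 `C=C1CC[C@H]2C(C)(C)CCC[C@]2(C)[C@H]1/C=C/C1=CC(=O)O[C@H]1O` — 2400 nM
compound 2 `C=C1CC[C@H]2C(C)(C)CCC[C@]2(C)[C@H]1CCC1=CC(=O)OC1` — 18800 nM
compound 3 `C=C1CC[C@H]2C(C)(C)CCC[C@]2(C)[C@H]1C/C=C1\CCOC1=O` — 30800 nM

Compound 3 gives the highest number of the three. Its nearest neighbour is compound 2, and the step of a 1.6-fold higher number from compound 2 to compound 3 (0.21 log units; within the scatter) lies within the scatter. Among the compounds with values here, compound 1 gives a clearly lower number than compound 3, but the two differ in more than one place, so only the pair of values speaks.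

Compound 4 `C=C1CC[C@H]2C(C)(C)CCC[C@]2(C)[C@H]1C/C=C1\CC(OC)OC1=O` differs from compound 3 by methoxy in place of hydrogen on a saturated ring carbon. Within the data shown here, no measured step alters a substituent on the lactone ring; the only step available, a 1.6-fold higher number from compound 2 to compound 3 (0.21 log units; within the scatter), exchanges whole lactone groups and does not bear directly on this change. Compound 4 is therefore expected to stay near compound 3, with a 1.5-fold lower number from compound 3 to compound 4 (0.19 log units; within the scatter) as the expected step. The estimate for compound 4 in this assay is 20000 nM, range 6000 nM to 60000 nM.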

Compound 4, half-maximal inhibitory concentration: 24600 nM
Compound 4: the middle estimate sits 1.2-fold (0.09 log units) below what was measured; the measured number falls inside the stated range.
By their numbers in this assay, from the lowest: compound 1; then compounds 2, 4 and 3 (each within the scatter of the next).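

In this assay the step is a 1.3-fold lower number from compound 3 to compound 4 (0.10 log units; within the scatter) for methoxy in place of hydrogen on a saturated ring carbon next to the ring oxygen, so this position takes the methoxy group without a change beyond the scatter. Earlier steps exchanged whole lactone groups, whereas this one alters only a substituent on the lactone ring. No measured evidence accompanies this result.

On these data alone, whether an amine, a carboxylic acid or a longer ether such as butoxy at this carbon would also stay within the scatter remains open. Also open, as far as these compounds go, is whether methoxy would give a similar step on the lactone of compound 2.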